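Fluoro to methoxy swap on the acetoxymethyl urea analogue

The source may hold more compounds than are shown below. What is called first, only, known or untested is meant among the compounds shown, and "the series" means these compounds.

Compound 1 `Cc1ccc(CN2CCC(CCN(Cc3ccc(-c4ccc(F)cc4)cc3)C(=O)NC(C)C)CC2)cc1`: 6.42 in an in vitro functional assay on HEK293 cells for antagonist activity at melanin-concentrating hormone receptor 1 (Homo sapiens), read by GTPgammaS binding, with a stated time of 45 min; on this read-out higher numbers stand for higher potency (the scale is a negative logarithm) and lower numbers for lower potency
Compound 2 `COc1ccc(-c2ccc(CN(CCC3CCN(Cc4ccc(C)cc4)CC3)C(=O)NC(C)C)cc2)cc1`: 6.34
Compound 3 `CC(=O)OCC(C)(C)NC(=O)N(CCC1CCN(Cc2ccc(C)cc2)CC1)Cc1ccc(-c2ccc(F)cc2)cc1`: 6.39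

Compound 3 stands second highest of the three numbers; its nearest neighbour is compound 1, higher by a margin within the scatter, and the furthest is compound 2, lower by a margin that is also within the scatter. All three measured compounds thus sit in one narrow band.

Compound 4 `COc1ccc(-c2ccc(CN(CCC3CCN(Cc4ccc(C)cc4)CC3)C(=O)NC(C)(C)COC(C)=O)cc2)cc1` is not yet measured. It differs from compound 3 by methoxy in place of fluoro on an aromatic carbon. The same change has been measured once, on the parent pair: a number 0.08 log units lower from compound 1 to compound 2 (within the scatter). The other measured step, a number 0.03 log units lower from compound 1 to compound 3 (within the scatter), shows that the acetoxymethyl group itself moves the number no further than the scatter. Nothing in the measured steps points to a sizeable move in either direction, so compound 4 is expected to stay close to compound 3, with the step of a number 0.08 log units lower from compound 3 to compound 4 (within the scatter) expected to fall within the scatter. The estimate for compound 4 is 6.31, expected to lie between 5.95 and 6.7.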

Compound 4, negative logarithm of the antagonist equilibrium constant: 6.19
Compound 4: middle estimate off by 0.12 log units, on the high side, within the range that was stated.
By their numbers in this assay, from the lowest: compounds 4, 2, 3 and 1 (each within the scatter of the next).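

Methoxy in place of fluoro on the acetoxymethyl analogue gives a number 0.20 log units lower from compound 3 to compound 4 (within the scatter) in this assay, so the 4-fluorophenyl to 4-methoxyphenyl change now stands on two cores and stays inside the scatter on both: the same change on two cores in this assay, a number 0.08 log units lower (within the scatter) from compound 1 to compound 2 and a number 0.20 log units lower (within the scatter) from compound 3 to compound 4, 0.12 log units apart, within the scatter of two such steps. Acetoxymethyl in place of hydrogen, now also read on the methoxy side, gives a number 0.15 log units lower from compound 2 to compound 4 (within the scatter), and the two readings agree: the same change on two cores in this assay, a number 0.03 log units lower (within the scatter) from compound 1 to compound 3 and a number 0.15 log units lower (within the scatter) from compound 2 to compound 4, 0.12 log units apart, within the scatter of two such steps. Across these four compounds, neither change moves the number beyond the scatter on either core, and the two changes show no measurable dependence on each other.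

From the compounds shown here alone, it remains open whether an amine or a carboxylic acid on this aromatic carbon would stay in the same narrow band. The same question stands for a longer chain in place of acetoxymethyl.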